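Swapping Methoxy and Fluorine for Methyl and Chlorine

This account rests on a few compounds, and the source may have more. Where it says the series, first, only, none or still open, it means among the compounds named here.

Compound 2 `COc1cc(F)ccc1-c1cc2c(cn1)ncn2-c1ccc(OC(F)F)cc1` stands second highest of three numbers in a functional assay on HL-60 cells (Homo sapiens) for activation, read by flow cytometry, with a stated time of 4 days (a higher number here means that more compound is needed for the effect, a lower number that less compound is needed), where compound 2 gives 93 nM. Compound 1 `COc1ccc(-n2cnc3cnc(-c4ccc(F)cc4C)cc32)cc1F` gives 10 nM and compound 3 `CC(C)Oc1cc(F)ccc1-c1cc2c(cn1)ncn2-c1ccc(OC(F)F)cc1` gives 1100 nM. Compound 4 `Cc1cc(Cl)ccc1-c1cc2c(cn1)ncn2-c1ccc(OC(F)F)cc1` differs from compound 2 in one place: 4-chloro-2-methylphenyl in place of 4-fluoro-2-methoxyphenyl on an aromatic carbon. Going by the values given here, no measured step matches this change. Among the compounds with values here, the only step, a 12-fold higher number from compound 2 to compound 3 (1.07 log units; beyond the scatter), shows that enlarging the group on the oxygen raised the number a lot, but says nothing about removing the oxygen or exchanging fluorine for chlorine. Compound 1 also has a methyl rather than a methoxy on this ring, yet its other aryl group differs too, so its lower number cannot be assigned to one change. For compound 4 a step of a 1.9-fold lower number from compound 2 to compound 4 (0.27 log units; within the scatter) is therefore expected, a modest one. Compound 4 is estimated at 50 nM in this assay, within 15 nM to 200 nM.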

Compound 4, half-maximal effective concentration: 28 nM
For compound 4 the middle estimate is 1.8-fold (0.25 log units) above the measured one; the measured number falls inside the stated range.
By their numbers in this assay, from the lowest: compound 1; then compound 4; then compound 2; then compound 3.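

Going from 4-fluoro-2-methoxyphenyl to 4-chloro-2-methylphenyl on this aromatic carbon gives a 3.3-fold lower number from compound 2 to compound 4 (0.52 log units; beyond the scatter) in this assay and so moves the number beyond the scatter. This shows that the oxygen, whose enlargement had raised the number, can be removed from this ring altogether while less compound is still needed for the effect. No measurement here explains this change. Two things changed together, so the step cannot be divided between the loss of the oxygen and the exchange of fluorine for chlorine. Going by these compounds, how an amine or a nitrile would behave on this ring remains open.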